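The source may report more compounds than this note shows. Statements on the series, on what has been measured and on what is new or still open speak of the compounds shown alone.

Measured so far:
- compound 1 `O=C1Nc2ccc(C(=O)c3ccco3)cc2/C1=C/c1ccc(O)nc1`: 26.5%
- compound 2 `O=C1Nc2ccc(C(=O)c3ccco3)cc2/C1=C/c1ccncc1`: 0.8%
- compound 3 `O=C1Nc2ccc(C(=O)NCc3ccccc3)cc2/C1=C/c1cc(Cl)c(O)c(Cl)c1`: -24%

In an assay on HeLa cells for inhibition of Kinesin-like protein KIF15 (Homo sapiens), read by microscopy, with stated times of 2 s and 20 s, tested at 750 nM (a higher number here means more inhibition at the concentration tested (going by the name of the read-out), a lower number less inhibition), compound 3 stands lowest of the three numbers; compound 2 gives 0.8% and compound 1 gives 26.5%, both beyond the scatter above it. Compound 4 `O=C1Nc2ccc(-c3ccco3)cc2/C1=C/c1cc(Cl)c(O)c(Cl)c1` is the unmeasured partner of compound 3. Change from compound 3 to compound 4: furan-2-yl in place of benzylcarbamoyl on an aromatic carbon. Within the data shown here, the only measured step, a number 25.7 percentage points lower from compound 1 to compound 2 (beyond the scatter), concerns the other end of the core and gives no guide to an exchange at this position. Among the measured compounds shown here, compound 1 carries a furan attached through a carbonyl, not directly, so it is no direct precedent either. Compound 4 is therefore expected near the lower part of the range, with a number 27 percentage points higher from compound 3 to compound 4 (beyond the scatter) as a guess; the estimate for compound 4 is 3% (range -25% to 32%).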

Compound 4, a percentage reported as inhibition, at one concentration (the size of the read-out at that concentration, not a potency): 33%
Estimate against measurement, compound 4: 30 percentage points below; the whole stated range lies below it.
By their numbers in this assay, from the lowest: compound 3; then compound 2; then compounds 1 and 4 (each within the scatter of the next).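

In this assay, an exchange at this aromatic carbon alone gives a large step (a number 57 percentage points higher from compound 3 to compound 4 (beyond the scatter)), so the read-out responds to this position as well as to the other end of the shared core. With that other end held constant, furan-2-yl bound directly carries the higher number and benzylcarbamoyl the lower. No measurement available here accounts for this step.

The compounds shown do not separate the loss of benzylcarbamoyl from the arrival of furan-2-yl. An amine or a carboxylic acid on this carbon would help to distinguish the two.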